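Exchanging one carboxyphenyl group for another

This account rests on a few compounds, and the source may have more. Where it says the series, first, only, none or still open, it means among the compounds named here.

In an ADME assay on a cell-free system (plasma, Rattus norvegicus) for metabolic stability, read by LC-MS, with a stated time of 1 h, at 37 degrees C, tested at 100 uM (on this read-out lower numbers stand for a less stable compound and higher numbers for a more stable compound), compound 1 `O=C1c2ccc(OCc3cccc(-c4ccccc4)c3)cc2CN1C1CCCC1` gives 95% as its result. Compound 2 `O=C1c2ccc(OCc3cccc(-c4ccc(C(F)(F)F)cc4F)c3)cc2CN1C1CCCC1` has the entry "not determined" (no result reported) and so offers no number. Compound 3 `Cc1ccc(C(=O)O)cc1-c1cccc(COc2ccc3c(c2)CN(C2CCCC2)C3=O)c1` gives 100% as its result, which is the top of the two numbers available but lies within the scatter of compound 1, so the pair cannot truly be ranked. Compound 4 `O=C(O)c1ccc(-c2cccc(COc3ccc4c(c3)CN(C3CCCC3)C4=O)c2)c(Cl)c1` carries 4-carboxy-2-chlorophenyl in place of 5-carboxy-2-methylphenyl on an aromatic carbon. Among the measured compounds shown here, the one measured step that bears on this change is a number 5 percentage points higher from compound 1 to compound 3 (within the scatter) and it put 5-carboxy-2-methylphenyl in place of phenyl without leaving the scatter. For the measured compounds named here, no measured compound carries 4-carboxy-2-chlorophenyl, so the evidence is thin. On that basis, a step beyond the scatter is not expected for compound 4 in this assay either. The estimated step is a number 3 percentage points lower from compound 3 to compound 4 (within the scatter) and it lies within the scatter. For compound 4 the estimate is 97% with an expected range from 87% to 100% for repeated measurements.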

Compound 4, percent of the compound remaining: 100%
Compound 4: the middle estimate sits 3 percentage points below what was measured, within the range that was stated.
By their numbers in this assay, from the lowest: compounds 1, 3 and 4 (each within the scatter of the next).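

In this assay the exchange of 5-carboxy-2-methylphenyl for 4-carboxy-2-chlorophenyl gives no change at the digits printed from compound 3 to compound 4 (within the scatter) and so stays inside the usual variation between repeats. Set against the plain phenyl group, the new group gives a number 5 percentage points higher from compound 1 to compound 4 (within the scatter) in the same way, so a second carboxyphenyl group, this one carrying chlorine rather than methyl, also shows no step beyond the scatter at this place in this assay. Nothing measured here offers a reason for this result.

Steps involving compound 2 cannot be read, as it has no number. Every group shown at this place is a phenyl ring, so it remains open whether a group of another kind, such as an aminomethyl group or a saturated ring like piperidine, would also stay within the scatter.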